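A methyl on the acid chain of compound 2

A few compounds are considered here, and "the series" means these few. Any claim that something is new, unique, unknown or untested is made for them only; others in the source may bear on it.

Compound 1 `O=C(O)Cn1nc(Cn2cc3cc(OCC4CC4)c(Cl)cc3n2)c2ccccc2c1=O` gives 1.4 h
Compound 2 `O=C(O)Cc1nn(Cc2cn3cc(OCC4CC4)c(Cl)cc3n2)c2ccccc2c1=O` gives 0.8 h

Both numbers come from an ADME assay on the whole organism (Mus musculus, strain CD1) for metabolic stability, read by LC-MS, with a stated time of 24 h, at a dose of 1 mg/kg by the intravenous route (on this read-out lower numbers stand for a shorter-lived compound and higher numbers for a longer-lived compound), and lie within the usual scatter of each other, so compound 2 is not set apart from compound 1. Compound 3 `C[C@H](C(=O)O)c1nn(Cc2cn3cc(OCC4CC4)c(Cl)cc3n2)c2ccccc2c1=O` differs from compound 2 by methyl in place of hydrogen on a saturated chain carbon bound to an aromatic carbon and a carbonyl carbon and so turns carboxymethyl to 1-carboxyethyl. Among the compounds with values here, no measured step shows what this change does in this assay and no shift beyond the scatter is expected in either direction. The estimate therefore starts from compound 2 at 0.8 h and stays close to it. The expected step is a 1.3-fold higher number from compound 2 to compound 3 (0.10 log units; within the scatter) and it lies within the scatter. Compound 3 is expected at 1 h (0.4 h to 2.5 h).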

Compound 3, half-life: 0.8 h
The estimate for compound 3 lay 1.3-fold (0.10 log units) above the measured number, within the range that was stated.
By their numbers in this assay, from the lowest: compounds 2, 3 and 1 (each within the scatter of the next).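

In this assay, methyl in place of hydrogen on a saturated chain carbon bound to an aromatic carbon and a carbonyl carbon gives no change at the digits printed from compound 2 to compound 3 (within the scatter). Within the data shown here, this is the first reading at this position, and on this one pair, the turn from carboxymethyl to 1-carboxyethyl leaves the half-life within the scatter. No evidence bears on this result. The compounds shown leave open how an ethyl, a second methyl or a hydroxyl on that carbon would read, and whether the opposite configuration there would read the same.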